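The source may report more compounds than this note shows. Statements on the series, on what has been measured and on what is new or still open speak of the compounds shown alone.

In a physicochemical assay for solubility, at pH 7 (on this read-out lower numbers stand for lower solubility and higher numbers for higher solubility), compound 1 `OC[C@@H](O[C@H]1CCCN(Cc2ncc[nH]2)[C@H]1c1ccccc1)c1cc(Cl)cc(Cl)c1` gives 120000 nM. Among the compounds with values here, the only other measured compound, compound 2 `O=C(O)c1ccc(CN2CCC[C@H](O[C@H](CO)c3cc(Cl)cc(Cl)c3)[C@@H]2c2ccccc2)cc1`, gives 85000 nM. Compound 1 therefore stands level with compound 2 within the scatter, and these two numbers set no order between them.

Compound 3 `O=C(O)c1ccc(CN2CCC[C@H](O[C@H](CO)c3cc(Cl)cc(Cl)c3)[C@@H]2c2ccccc2)c([N+](=O)[O-])c1` shares the core of compound 1 and differs from it as follows: 4-carboxy-2-nitrophenyl in place of 1H-imidazol-2-yl on a saturated chain carbon bound to an amine nitrogen in a ring. The exchange lies on a saturated chain carbon bound to an amine nitrogen in a ring.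

Within the data shown here, one measured step bears on it: a 1.4-fold lower number from compound 1 to compound 2 (0.15 log units; within the scatter), where 4-carboxyphenyl takes the place of 1H-imidazol-2-yl at that same position. This step is small and stays within the scatter. Among the measured compounds shown here, no measured compound carries 4-carboxy-2-nitrophenyl, so the data give no direct read on that group, and the range has to stay wide.

For the measured compounds named here, with only that one step as a guide, no shift beyond the scatter is expected, though a slight lean towards a lower number is allowed for. The expected step is a 1.7-fold lower number from compound 1 to compound 3 (0.23 log units; within the scatter). For compound 3 the estimated value is 70000 nM, with an expected range of 25000 nM to 150000 nM.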

Compound 3, solubility: 110000 nM
Compound 3: the middle estimate sits 1.6-fold (0.20 log units) below what was measured; low and high end bracket the measured number.
By their numbers in this assay, from the lowest: compounds 2, 3 and 1 (each within the scatter of the next).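

In this assay the step of a 1.1-fold lower number from compound 1 to compound 3 (0.04 log units; within the scatter) shows that 4-carboxy-2-nitrophenyl, with 12 heavy atoms, can replace 1H-imidazol-2-yl, with 5, on a saturated chain carbon bound to an amine nitrogen in a ring while the read-out stays within the scatter. Within the data shown here, the step of a 1.3-fold higher number from compound 2 to compound 3 (0.11 log units; within the scatter) adds the first reading on nitro in place of hydrogen on an aromatic carbon, and this change also stays within the scatter, so none of the three compounds is set apart from the others by these numbers. No measurement shown here explains why these steps are so small.

On these data alone, all three compounds carry an aromatic ring on this chain carbon and share the rest of the core, so it remains open whether a plain alkyl chain, a dimethylamino-bearing chain or a saturated ring there would give a step beyond the scatter. As far as these compounds go, it is also open whether a methyl ester or a primary amide in place of the carboxylic acid of compound 2 would leave the read-out within the scatter.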